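Acetyl in place of pyridin-2-yl on compound 2

The source may hold more compounds than are shown below. What is called first, only, known or untested is meant among the compounds shown, and "the series" means these compounds.

In a functional assay on A2780 cells (Homo sapiens) for cytotoxicity (a higher number here means a weaker inhibitor, a lower number a stronger inhibitor), compound 1 `CC(C)(CO)CNCc1ccc(Nc2ncc(SCc3ncc(C(C)(C)C)o3)s2)nc1` gives 3 nM, compound 2 `CC(C)(C)c1cnc(CSc2cnc(Nc3ccccn3)s2)o1` gives 10 nM and compound 3 `CC(C)(C)c1cnc(CSc2cnc(Nc3ccc(S(=O)(=O)NCCO)cc3)s2)o1` gives 69 nM, so compound 2 holds the middle place of the three. Compound 4 `CC(=O)Nc1ncc(SCc2ncc(C(C)(C)C)o2)s1` carries acetyl in place of pyridin-2-yl on a nitrogen on an aromatic ring. Among the compounds with values here, the only measured step, a 3.3-fold higher number from compound 1 to compound 2 (0.52 log units; beyond the scatter), is modest but beyond the scatter, and it lies elsewhere on the molecule, so it bears only indirectly. Within the data shown here, no measured step covers this exchange. Compound 3, with a different group on that nitrogen, stands higher at 69 nM. A similar rise is therefore expected in this assay, with an estimated 12-fold higher number from compound 2 to compound 4 (1.08 log units; beyond the scatter). The estimate for compound 4 is 120 nM, with an expected range of 30 nM to 500 nM.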

Compound 4, half-maximal inhibitory concentration: 50 nM
Estimate against measurement, compound 4: 2.4-fold (0.38 log units) above; low and high end bracket the measured number.
By their numbers in this assay, from the lowest: compound 1; then compound 2; then compounds 4 and 3 (each within the scatter of the next).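

Within the data shown here, compound 4 gives the first direct reading of this exchange: in this assay, moving from pyridin-2-yl to acetyl brings a 5.0-fold higher number from compound 2 to compound 4 (0.70 log units; beyond the scatter). The nitrogen therefore tolerates a group with no ring, and compound 4 lies within the scatter of compound 3, which keeps an aromatic ring at this place. No available evidence explains the difference between pyridin-2-yl and acetyl. The compounds shown leave open how a longer acyl chain or a free amine would read at this nitrogen.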